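From 2-methylphenyl to cyclohexyl on an amide-type nitrogen

This account rests on a few compounds, and the source may have more. Where it says the series, first, only, none or still open, it means among the compounds named here.

- compound 1 `COc1ccccc1N(C)C(=O)N1CCC(c2nc(-c3ccc4ccccc4n3)no2)CC1`: 3100 nM
- compound 2 `Cc1ccccc1NC(=O)N1CCC(c2nc(-c3ccc4ccccc4n3)no2)CC1`: 440 nM

Among the compounds with values here, in a functional assay on Shh Light II cells (Mus musculus) for inhibition, read by a luciferase reporter (on this read-out higher numbers stand for weaker inhibition and lower numbers for stronger inhibition), compound 2 holds the lower of the two numbers so far. The next molecule, compound 3 `O=C(NC1CCCCC1)N1CCC(c2nc(-c3ccc4ccccc4n3)no2)CC1`, differs from it in one place: cyclohexyl in place of 2-methylphenyl on an amide-type nitrogen. Put simply, this is cyclohexyl in place of 2-methylphenyl on an amide-type nitrogen.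

Within the data shown here, only one measured step bears on this change: a 7.0-fold lower number from compound 1 to compound 2 (0.85 log units; beyond the scatter). It shows that a swap on the carbonyl carbon can move the number beyond the scatter. However, compound 1 and compound 2 both carry an aromatic ring, so no measurement yet shows the effect of a non-aromatic ring, and the direction remains uncertain. The expected step, smaller than the measured one and leaning towards weaker inhibition, is a 2.3-fold higher number from compound 2 to compound 3 (0.36 log units; beyond the scatter). The estimate for compound 3 is 1000 nM, with an expected range of 250 nM to 4000 nM.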

Compound 3, half-maximal inhibitory concentration: 57 nM
Compound 3: middle estimate off by 18-fold (1.24 log units), on the high side, and the stated range ends above it.
By their numbers in this assay, from the lowest: compound 3; then compound 2; then compound 1.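

Swapping 2-methylphenyl for cyclohexyl on the amide-type nitrogen gives a 7.7-fold lower number from compound 2 to compound 3 (0.89 log units; beyond the scatter) in this assay and so shows that this position does not need an aromatic ring, since the non-aromatic ring goes with stronger inhibition here. Replacing (2-methoxyphenyl)(methyl)amino on the carbonyl carbon with cyclohexylamino gives a 54-fold lower number from compound 1 to compound 3 (1.74 log units; beyond the scatter) and is the largest step among these compounds, so this one position spans a wide range of inhibition. Nothing measured here accounts for the gain.

Cyclohexyl is the only non-aromatic ring shown, so it remains open whether cyclopentyl, cycloheptyl or an open chain such as hexyl would do as well. As far as these compounds go, it is also open whether a cyclohexyl ring carrying a hydroxyl group or an amine would keep the stronger inhibition.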